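Working notes on cytotoxicity in a small series

This account rests on a few compounds, and the source may have more. Where it says the series, first, only, none or still open, it means among the compounds named here.

Measured so far:
compound 1, `Cc1c(O)ccc2c1[C@H](Cn1cc(-c3ccccn3)nn1)[C@@]13CC(=O)[C@@](C)(CC[C@@H]21)C3`, in a functional assay on A549 cells (Homo sapiens) for cytotoxicity, read by MTT assay, with a stated time of 4 days; a higher number here means a weaker inhibitor, a lower number a stronger inhibitor: > 20000 nM
compound 2, `C=C1C[C@]23C[C@@]1(O)CC[C@@H]2c1cccc(C)c1[C@@H]3Cn1cc(-c2ccc(OC)cc2)nn1`, in this assay: > 20000 nM

Compound 1 returns only a limit in this assay, > 20000 nM. Compound 2 also returns only a limit in this assay, > 20000 nM. Among the measured compounds shown here, compound 2 therefore stands at the same limit as the one other value shown, (the limit of > 20000 nM in this assay, at which 2 of the 2 values shown sit), and no step between measured compounds can be counted; nothing in the numbers places compound 2 above or below compound 1.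

Compound 3, `C=C1C[C@]23C[C@@]1(O)CC[C@@H]2c1cccc(C)c1[C@@H]3Cn1cc(-c2ccccc2)nn1`, is not yet measured. Compared with compound 2 the change is hydrogen in place of methoxy on an aromatic carbon.

For the measured compounds named here, no measured step is available on which to size this change. The expected step from compound 2 to compound 3 is a step that the limit leaves unreadable from compound 2 to compound 3, that is, nothing beyond the usual scatter. Compound 3 is expected to give about 30000 nM, within 8000 nM to 150000 nM, most likely reported as a limit rather than a number.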

Compound 3, half-maximal inhibitory concentration: > 20000 nM
Compound 3: only a limit was reported; the forecaster's own chance of this, stated with the estimate: 85%; the middle value is on the limit's open side.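

Compound 2 and compound 3 both sit at a limit in this assay, so no step can be read for the change from 4-methoxyphenyl to phenyl: the limit of > 20000 nM in this assay, at which 3 of the 3 values shown sit.

The compounds shown leave open how these two groups compare, and whether any compound of the series gives a number rather than a limit in this assay.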